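From Methoxy to Trifluoromethoxy on a Weak Jurkat Activator

A few compounds are considered here, and "the series" means these few. Any claim that something is new, unique, unknown or untested is made for them only; others in the source may bear on it.

Compound 1 `Cc1cccc(-c2ccc(NCc3ccccc3O)cc2)c1`: 9190 nM
Compound 2 `COc1cccc(-c2ccc(NCc3ccccc3O)cc2)c1`: "not active" (no number reported)

Of the compounds shown here, two sharing one core have been tested in a functional assay on Jurkat cells (Homo sapiens) for activation, with a stated time of 24 h; on this read-out lower numbers stand for an effect already at smaller amounts and higher numbers for an effect only at larger amounts of compound. Compound 1 gives 9190 nM, a weak effect. Compound 2 is reported in this assay only as "not active" (no number reported), so no number places it on the scale; all that can be said is that it showed no measurable effect under the same conditions.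

The next compound, compound 3 `Oc1ccccc1CNc1ccc(-c2cccc(OC(F)(F)F)c2)cc1`, differs from compound 2 by trifluoromethyl in place of methyl on an oxygen on an aromatic ring. Among the measured compounds shown here, there is no number for compound 2, so no step in this assay can be computed for this change. The only numeric anchor on the shared core is the weak value of compound 1. Nothing here shows that exchanging methyl for trifluoromethyl on that oxygen moves the read-out at all; the most that can be expected is a value in the same weak region as compound 1, with a real chance that no number is reached again.

Compound 3 is therefore estimated at 15000 nM, with an expected range from 4000 nM to 60000 nM.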

Compound 3, half-maximal effective concentration: "not active" (no number reported)
Compound 3 has no reported number here; the estimate stays without a comparison.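

Compound 2 and compound 3 are both reported in this assay only as "not active", so no step can be read between them. No other data here bear on this result. With compound 1 at 9190 nM as the only number on the shared core, the compounds shown leave open whether methoxy and trifluoromethoxy differ at all.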